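The source may report more compounds than this note shows. Statements on the series, on what has been measured and on what is new or still open speak of the compounds shown alone.

Measured compounds:
compound 1 `CCCN(Cc1ccc(OCCn2c(=O)ccn(C)c2=O)c(C)c1)C(CC(=O)O)c1ccc(Cl)cc1` – 23%
compound 2 `CCCN(Cc1ccc(OCCn2c(=O)ccn(C)c2=O)c(OC)c1)C(CC(=O)O)c1ccc(Cl)cc1` – 50%
compound 3 `COc1cc(CN(CC(C)C)C(CC(=O)O)c2ccc(Cl)c(F)c2)ccc1OCCN1C(=O)CCC1=O` – 57%

These three compounds were tested in an ADME assay on liver (Mus musculus) for metabolic stability, read by LC-MS, using microsomes and NADPH; a lower number here means that less of the compound is left, a higher number that more of the compound is left. Compound 2 gives 50%, and the change methyl in place of methoxy on an aromatic carbon gives a number 27 percentage points lower from compound 2 to compound 1 (beyond the scatter). Compound 3 gives 57%; the difference between the core of compound 3 and the core of compound 2 is not broken down here. The unmeasured compound 4 `Cc1cc(CN(CC(C)C)C(CC(=O)O)c2ccc(Cl)c(F)c2)ccc1OCCN1C(=O)CCC1=O` relates to compound 3 by methyl in place of methoxy on an aromatic carbon, the same kind of change as from compound 2 to compound 1, though the place differs: in compound 3 the carbon is ortho to a 2-(2,5-dioxopyrrolidin-1-yl)ethoxy group, while in compound 2 it is ortho to a large group. The step is estimated at a number 22 percentage points lower from compound 3 to compound 4 (beyond the scatter), because the same kind of change gave a number 27 percentage points lower from compound 2 to compound 1 (beyond the scatter). Compound 4 is therefore expected to give 35%, within 20% to 50%.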

Compound 4, percent of the compound remaining: 33%
Compound 4: middle estimate off by 2 percentage points, on the high side, within the range that was stated.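

In this assay, methyl in place of methoxy on an aromatic carbon gives a number 24 percentage points lower from compound 3 to compound 4 (beyond the scatter), and this step agrees with the one seen earlier on the other core: the same change on two cores in this assay, a number 27 percentage points lower (beyond the scatter) from compound 2 to compound 1 and a number 24 percentage points lower (beyond the scatter) from compound 3 to compound 4, 3 percentage points apart, within the scatter of two such steps Across these two cores, then, the change carried over in the same direction and at a similar size. This rests on two pairs alone, so it shows neither why the number falls nor whether the step would hold on a further core.

The compounds shown leave open how an ethyl, a chlorine or a hydroxyl would compare on that aromatic carbon. They also leave open whether any single difference between the two cores affects the size of the step.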